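The source may report more compounds than this note shows. Statements on the series, on what has been measured and on what is new or still open speak of the compounds shown alone.

Measured so far in a functional assay on HepG2 cells (Homo sapiens) for inhibition, read by MTT assay, with a stated time of 72 h (a lower number here means a stronger inhibitor, a higher number a weaker inhibitor), on the shared core:
- compound 1 (`CC(=O)Oc1cc(C(=O)C2=C(O)[C@]3(CC=C(C)C)C[C@@H](C/C=C(\C)CCC=C(C)C)[C@](C)(CCC=C(C)C)[C@](CC=C(C)C)(C2=O)C3=O)ccc1O`) gives > 20000 nM as a limit
- compound 2 (`CC(=O)Oc1ccc(C(=O)C2=C(O)[C@]3(CC=C(C)C)C[C@@H](C/C=C(\C)CCC=C(C)C)[C@](C)(CCC=C(C)C)[C@](CC=C(C)C)(C2=O)C3=O)cc1OC(C)=O`) gives > 20000 nM as a limit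

Compound 1 sits at the limit of > 20000 nM in this assay, at which 2 of the 2 values shown sit, and so has a limit, not a number. Compound 3 (`CC(C)=CCC/C(C)=C/C[C@@H]1C[C@]2(CC=C(C)C)C(=O)[C@@](CC=C(C)C)(C(=O)C(C(=O)c3ccc(O)c(OC(=O)CCCC[C@@H]4SCC5NC(=O)NC54)c3)=C2O)[C@@]1(C)CCC=C(C)C`) differs from compound 1 by one change: a group of 12 heavy atoms (8 carbon, 2 nitrogen, 1 oxygen, 1 sulfur; one five-membered non-aromatic ring with 1 hetero atom, one five-membered non-aromatic ring with 2 hetero atoms) in place of a hydrogen atom, on a saturated chain carbon bound to a carbonyl carbon in the words of the count. For the measured compounds named here, the one measured step (a step that the two limits leave unreadable from compound 1 to compound 2) puts acetyl in place of hydrogen on an oxygen on an aromatic ring. Its size cannot be read, and it bears only loosely on the group entering in compound 3. Going by the values given here, no step of known size can be carried over, so no shift beyond the scatter is expected in this assay and the estimated step (a number no higher from compound 1 to compound 3 (the limit leaves the size open)) may again end in a limit. Compound 3 is expected near 20000 nM with an estimated range from 8000 nM to 40000 nM (expected values only).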

Compound 3, half-maximal inhibitory concentration: 14600 nM
Compound 3: middle estimate off by 1.4-fold (0.14 log units), on the high side; the measured number falls inside the stated range.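

For the compounds shown here, compound 3 gives the only number so far in this assay, so the group of 12 heavy atoms, on a saturated chain carbon bound to a carbonyl carbon, is tolerated without loss of a readable value. The change gives an at least 1.3-fold lower number from compound 1 to compound 3 (0.13 log units; that floor lies within the scatter); this is only a floor, so a real gain is neither shown nor excluded. Compound 1 and compound 2 remain limits, and the step between them cannot be read: the limit of > 20000 nM in this assay, at which 2 of the 3 values shown sit.

From the compounds shown here alone, the true size of the step from the core of compound 1 remains unknown, and one compound cannot show which part of the entering group matters. Going by these compounds, whether a plain longer chain, an amine or a carboxylic acid at this place would give a lower number than compound 3 also stays open.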